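Trading a methoxymethyl for a methyl on the piperidine

The source may hold more compounds than are shown below. What is called first, only, known or untested is meant among the compounds shown, and "the series" means these compounds.

Three compounds share a core and have been run in an assay on isolated protein for displacement of a labelled ligand from metabotropic glutamate receptor 5 (Homo sapiens), with a stated time of 60 min, tested at 1 uM; a lower number here means less inhibition, a higher number more inhibition at the concentration tested (going by the name of the read-out). Compound 1 `CC1CCN(c2c(S(=O)(=O)c3cc(F)cc(F)c3)cnc3cc(Cl)ccc23)CC1` gives 94% in this assay, and compound 2 `Cc1ccc(S(=O)(=O)c2cnc3ccc(Cl)cc3c2N2CCC(C)CC2)cc1` gives 95%. Compound 3 `COCC1CCN(c2c(S(=O)(=O)c3cc(F)cc(F)c3)cnc3cc(F)ccc23)CC1` gives 83%, the lowest of the three numbers; its gaps to compound 1 and to compound 2 both lie beyond the usual scatter.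

Compound 4 `CC1CCN(c2c(S(=O)(=O)c3cc(F)cc(F)c3)cnc3cc(F)ccc23)CC1` has not yet been measured. It differs from compound 3 in one place: hydrogen in place of methoxy on a saturated chain carbon bound to a saturated ring carbon. Going by the values given here, no directly comparable pair of measured compounds shows this exact change, so its size is not known from the data. Since compound 1 also carries the 4-methylpiperidin-1-yl group and gives a high reading in this assay, compound 4 is expected to move upward from compound 3, with an estimated step of a number 7 percentage points higher from compound 3 to compound 4 (within the scatter) that is modest but beyond the scatter. On that basis compound 4 is estimated to give 90% in this assay, with a likely range from 80% to 97%.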

Compound 4, a percentage reported as inhibition, at one concentration (the size of the read-out at that concentration, not a potency): 77%
Beside the measured number, compound 4's estimate is 13 percentage points above it; the measured number lies below the stated range.
By their numbers in this assay, from the lowest: compounds 4 and 3 (each within the scatter of the next); then compounds 1 and 2 (each within the scatter of the next).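

In this assay, going from 4-(methoxymethyl)piperidin-1-yl to 4-methylpiperidin-1-yl on the fluoro-bearing core gives a number 6 percentage points lower from compound 3 to compound 4 (within the scatter), so on this core the change has no effect that can be told from the scatter. The step that does stand out lies elsewhere: with the 4-methylpiperidin-1-yl group held constant, fluoro in place of chloro on an aromatic carbon gives a number 17 percentage points lower from compound 1 to compound 4 (beyond the scatter), so the high reading of the chloro compound does not carry over to its fluoro counterpart. No measurement in hand accounts for either step.

The compounds shown leave open whether the methoxymethyl group would read the same on the chloro-bearing core. They also leave open how a hydroxymethyl group or a longer chain such as ethyl would read at this place on the piperidine.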